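From chloro to bromo on compound 2

The source may report more compounds than this note shows. Statements on the series, on what has been measured and on what is new or still open speak of the compounds shown alone.

Compound 1 `O=[N+]([O-])c1cc(C(F)(F)F)cc([N+](=O)[O-])c1Oc1ccc(Cl)cc1/C=N\OCc1ccccc1Cl` gives 3950 nM
Compound 2 `O=[N+]([O-])c1cc(C(F)(F)F)cc([N+](=O)[O-])c1Oc1ccc(Cl)cc1/C=N\OCc1ccc(Cl)cc1Cl` gives 1140 nM

Compound 2 has the lower of the two numbers in a functional assay on MCF7 cells (Homo sapiens) for antiproliferative activity, read by MTT assay, with a stated time of 48 h (a lower number here means a stronger inhibitor, a higher number a weaker inhibitor), and compound 1 sits above it (a 3.5-fold lower number from compound 1 to compound 2 (0.54 log units; beyond the scatter)). That modest step put chloro in place of hydrogen on an aromatic carbon. Compound 3 `O=[N+]([O-])c1cc(C(F)(F)F)cc([N+](=O)[O-])c1Oc1ccc(Br)cc1/C=N\OCc1ccc(Cl)cc1Cl` has not yet been measured and carries bromo in place of chloro on an aromatic carbon. Among the measured compounds shown here, no measured step swaps one halogen for another, so the single step available (a 3.5-fold lower number from compound 1 to compound 2 (0.54 log units; beyond the scatter)) is only a loose guide. The starting point is therefore compound 2 at 1140 nM and no step beyond the scatter is expected in this assay in either direction. The estimated step is a 1.0-fold lower number from compound 2 to compound 3 (0.02 log units; within the scatter) and stays within the scatter. For compound 3 the estimate is 1100 nM with an expected range from 550 nM to 2200 nM for repeat measurements.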

Compound 3, half-maximal inhibitory concentration: 1340 nM
Compound 3: the middle estimate sits 1.2-fold (0.09 log units) below what was measured; low and high end bracket the measured number.
By their numbers in this assay, from the lowest: compounds 2 and 3 (each within the scatter of the next); then compound 1.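

In this assay, replacing chloro with bromo on the ring carbon that is meta to a large group and para to a large group gives a step within the scatter (a 1.2-fold higher number from compound 2 to compound 3 (0.07 log units; within the scatter)), so compound 2 and compound 3 cannot be told apart. The earlier step, made at a different place in the molecule, showed that adding a chloro to an aromatic carbon can move the number beyond the scatter. This result adds that, at this new position, one halogen can stand in for the other without a change this assay can detect, though nothing available explains why.

The compounds shown leave open whether this position accepts only halogens. A hydrogen, a methoxy group or an amine in the same place could still move the number in either direction.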